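Adding Chloro to the Benzyl Group of Compound 2

The source may report more compounds than this note shows. Statements on the series, on what has been measured and on what is new or still open speak of the compounds shown alone.

Compound 2: `CCNc1nc(-c2ccccc2)nc2c1nnn2Cc1ccccc1` — 91 nM
Compound 1: `CNc1nc(-c2ccccc2)nc2c1nnn2Cc1ccccc1Cl` — 191 nM

In an assay on Cerebral cortex for displacement of a labelled ligand from adenosine receptor A1 (Bos taurus) (on this read-out lower numbers stand for stronger inhibition and higher numbers for weaker inhibition), compound 2 gives 91 nM, the lowest of the two numbers shown. For the measured compounds named here, compound 1 gives 191 nM, a higher number that lies beyond the scatter, but it differs from compound 2 in more than one place, so the two values alone fix no single step. Compound 3, `CCNc1nc(-c2ccccc2)nc2c1nnn2Cc1ccccc1Cl`, arises from compound 2 by chloro in place of hydrogen on an aromatic carbon. Going by the values given here, no measured step isolates this change, so its size is open; the expectation is a step of no more than the scatter, if anything toward a slightly higher number. The expected step from compound 2 to compound 3 is a 1.3-fold higher number from compound 2 to compound 3 (0.10 log units; within the scatter). Compound 3 is estimated at 115 nM, with a range from 40 nM to 330 nM.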

Compound 3, inhibition constant: 463 nM
For compound 3 the middle estimate is 4.0-fold (0.60 log units) below the measured one; measured number above the stated range.
By their numbers in this assay, from the lowest: compound 2; then compound 1; then compound 3.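

In this assay, chloro in place of hydrogen on an aromatic carbon is far from a silent change: going from benzyl to 2-chlorobenzyl gives a 5.1-fold higher number from compound 2 to compound 3 (0.71 log units; beyond the scatter) and so weakens inhibition. With the chloro in place, methyl in place of hydrogen on the chain carbon bound to the nitrogen also weakens it, giving a 2.4-fold higher number from compound 1 to compound 3 (0.38 log units; beyond the scatter) in the same read-out. Nothing available explains either step.

Still open, on these data alone, is whether fluoro or methoxy in place of this chloro would weaken inhibition as much. Also open, as far as these compounds go, is how a longer chain, such as propyl, on that nitrogen would behave.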